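The source may report more compounds than this note shows. Statements on the series, on what has been measured and on what is new or still open speak of the compounds shown alone.

Measured so far:
- compound 1 `COc1cccc(/C=C/C(=O)Nc2cc(OC)c(OC)c(OC)c2)c1` — in a functional assay on DU-145 cells (Homo sapiens) for cytotoxicity, read by MTT assay, with a stated time of 72 h (a higher number here means a weaker inhibitor, a lower number a stronger inhibitor), compound 1 gives 3200 nM
- compound 2 `COc1ccc(C(=O)c2cc(OC)c(OC)c(OC)c2)cc1NC(=O)/C=C/c1cc(OC)c(OC)c(OC)c1` — in this assay compound 2 gives 6300 nM

Going by the values given here, only two compounds carry a number, and they sit within the usual scatter of one another: compound 2 is not separated from compound 1 on these data, and no ordering between them is claimed. Among the compounds with values here, no pair differing in a single place has been measured, so there is no step of known size to lean on.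

The next compound, compound 3 `COc1ccc(C(=O)c2cc(OC)c(OC)c(OC)c2)cc1NC(=O)/C=C/c1ccc(OC)c(OC)c1`, differs from compound 2 in one place: hydrogen in place of methoxy on an aromatic carbon — hydrogen in place of methoxy on an aromatic carbon, on the ring that carries the cinnamoyl chain. With nothing measured on either side of this change, the expectation is a step of modest size at most, with no firm direction: a 1.1-fold lower number from compound 2 to compound 3 (0.02 log units; within the scatter) is what is expected here, and a result within the scatter of compound 2 would not surprise. On that basis compound 3 is estimated at 6000 nM in this assay, with a plausible range from 2000 nM to 18000 nM.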

Compound 3, half-maximal inhibitory concentration: 10200 nM
Estimate against measurement, compound 3: 1.7-fold (0.23 log units) below; the range from low to high includes it.
By their numbers in this assay, from the lowest: compounds 1, 2 and 3 (each within the scatter of the next, the first and the last beyond it).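

In this assay, the change from 3,4,5-trimethoxyphenyl to 3,4-dimethoxyphenyl gives the series its first step of known size: a 1.6-fold higher number from compound 2 to compound 3 (0.21 log units; within the scatter). This step lies within the usual scatter, so compound 3 is not separated from compound 2, and hydrogen in place of methoxy at this position, on an aromatic carbon ortho to a methoxy group and meta to a large group, has no resolved effect on these data. No measurement available here bears on what lies behind this result.

As far as these compounds go, whether another group at this same position, such as a hydroxyl, a fluorine, an amine or a longer ether chain, would separate from compound 2 stays open. A single step also leaves open whether hydrogen in place of methoxy would read the same at the other methoxy groups of compound 3 or in a different core.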